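A few compounds are considered here, and "the series" means these few. Any claim that something is new, unique, unknown or untested is made for them only; others in the source may bear on it.

Working notes on a set of four esters that share one core, tested in an assay on cells (strain Sprague-Dawley) for inhibition of Polyunsaturated fatty acid 5-lipoxygenase (Rattus norvegicus), with a stated time of 30 min; a lower number here means a stronger inhibitor, a higher number a weaker inhibitor. Compound 1, `CC(=O)Oc1ccc(/C=C/C(=O)OCCSc2nc(-c3ccc(S(C)(=O)=O)cc3)n(-c3ccc(C(F)(F)F)cc3)n2)cc1OC(C)=O`, gives 1060 nM. Compound 2, `CC(=O)Oc1ccc(/C=C/C(=O)OCCCSc2nc(-c3ccc(S(C)(=O)=O)cc3)n(-c3ccc(Br)cc3)n2)cc1OC(C)=O`, gives 990 nM. Compound 3, `CC(=O)Oc1ccc(/C=C/C(=O)OCCSc2nc(-c3ccc(S(N)(=O)=O)cc3)n(-c3ccc(Br)cc3)n2)cc1OC(C)=O`, gives 1050 nM. Compound 3 therefore holds the second highest of the three numbers; its nearest neighbour is compound 1, whose number sits within the scatter of that of compound 3, and its furthest neighbour is compound 2, whose number also sits within the scatter. The three measured values show no spread beyond the scatter, so no order among compounds 1, 2 and 3 can be read from them.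

Compound 4, `CC(=O)Oc1ccc(/C=C/C(=O)OCCSc2nc(-c3ccc(S(N)(=O)=O)cc3)n(-c3ccccc3)n2)cc1OC(C)=O`, has not yet been measured in this assay. It differs from compound 3 in one place: hydrogen in place of bromo on an aromatic carbon. Among the measured compounds shown here, no pair of measured compounds shows this change, so no step size for it is known from this set; the three measured values, all close to each other despite three different groups on that ring, give no ground to expect a large move. The step of a 1.4-fold higher number from compound 3 to compound 4 (0.15 log units; within the scatter) is therefore estimated as small, if anything a slightly higher number, and quite possibly none beyond the scatter. For compound 4 the expected value in this assay is 1500 nM, with a range from 700 nM to 3500 nM.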

Compound 4, half-maximal inhibitory concentration: 1110 nM
The estimate for compound 4 lay 1.4-fold (0.13 log units) above the measured number; measured number inside the range.
By their numbers in this assay, from the lowest: compounds 2, 3, 1 and 4 (each within the scatter of the next).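

In this assay, among the compounds shown here, the change from 4-bromophenyl to phenyl, on an aromatic carbon para to a large group, gives a 1.1-fold higher number from compound 3 to compound 4 (0.02 log units; within the scatter) and so provides the first direct reading of this position. The earlier compounds shown here could only suggest it. They differed from one another in more than one place. With the rest of the molecule held constant, bromo and hydrogen at this position cannot be told apart in this assay, so bromo is not needed to keep the number of compound 4 in the range of compound 3. This finding holds for this one pair only, and no independent measurement bears on the result.

As far as these compounds go, whether a different group at this position, such as an amine, a carboxylic acid or a methoxy group, would move the number beyond the scatter remains open. Also open, from the compounds shown here alone, is whether the change from bromo to hydrogen would read the same with the longer chain of compound 2 or the methylsulfonyl group shared by compound 1 and compound 2.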